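The source may report more compounds than this note shows. Statements on the series, on what has been measured and on what is new or still open speak of the compounds shown alone.

Two members of the series have numbers in a functional assay on A549 cells (Homo sapiens) for antiproliferative activity, read by MTT assay, with a stated time of 48 h (on this read-out lower numbers stand for stronger inhibition and higher numbers for weaker inhibition), so far. Compound 1, `CCCCCCC1(O)C(=O)Nc2ccc(Nc3ccc(OC)cc3)cc21`, gives 18600 nM in this assay. Compound 2, `CCCCC1(O)C(=O)Nc2ccc(Nc3ccc(C(F)(F)F)cc3)cc21`, gives 2300 nM in this assay, the lower of the two numbers shown, with compound 1 sitting well beyond the scatter above it. The next compound, compound 3 with structure `CCCCCCC1(O)C(=O)Nc2ccc(Nc3ccc(C(F)(F)F)cc3)cc21`, differs from compound 2 by ethyl in place of hydrogen on a saturated chain carbon, four bonds along the chain from a saturated ring carbon. Among the compounds with values here, no measured pair isolates this change. The step from compound 2 to compound 3 is expected to be a 1.3-fold higher number from compound 2 to compound 3 (0.12 log units; within the scatter), a small weakening at most, not clearly beyond the scatter. Compound 3 is therefore estimated at 3000 nM in this assay, with a range of 1200 nM to 8000 nM.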

Compound 3, half-maximal inhibitory concentration: 2800 nM
For compound 3 the middle estimate is 1.1-fold (0.03 log units) above the measured one; the range from low to high includes it.
By their numbers in this assay, from the lowest: compounds 2 and 3 (each within the scatter of the next); then compound 1.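

In this assay, ethyl in place of hydrogen on the saturated chain carbon gives a 1.2-fold higher number from compound 2 to compound 3 (0.09 log units; within the scatter) and so does not separate these two compounds. Within the data shown here, compound 3 also gives the first comparison at the aromatic carbon that differs in one place: trifluoromethyl in place of methoxy gives a 6.6-fold lower number from compound 1 to compound 3 (0.82 log units; beyond the scatter) with the hexyl chain held constant. No measurement here gives a cause for either step. As far as these compounds go, whether the chain change reads the same with methoxy on the aromatic carbon remains open. So does the outcome with an octyl chain, or with an amine or a carboxylic acid in place of trifluoromethyl.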